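The source may report more compounds than this note shows. Statements on the series, on what has been measured and on what is new or still open speak of the compounds shown alone.

Compound 1 `C=CC(=O)N1CC[C@H](N2C(=O)N(c3ccccc3)Cc3cnc(Nc4ccc(N5CCN(C)CC5)cc4)nc32)C1` is the reference point of this series. In an ADME assay on the whole organism (plasma, strain Sprague-Dawley) for pharmacokinetics, with Rattus norvegicus as the target, read by LC-MS, at a dose of 25 mg/kg by the oral route (a higher number here means more compound in the circulation at the dose given, a lower number less compound in the circulation), compound 1 gives 2310 ng.h/mL, and the two other measured compounds sit within the scatter of it on either side: compound 2 `C=CC(=O)N1CC[C@H](N2C(=O)N(c3ccccc3)Cc3cnc(Nc4ccc(N5CCN(C)CC5)cc4OC)nc32)C1` gives 2130 ng.h/mL and compound 3 `C=CC(=O)N1CC[C@H](N2C(=O)N(c3ccccc3)Cc3cnc(Nc4ccc(N5CCN(C)CC5)c(C)c4)nc32)C1` gives 2490 ng.h/mL. The step of a 1.1-fold lower number from compound 1 to compound 2 (0.04 log units; within the scatter) and the step of a 1.1-fold higher number from compound 1 to compound 3 (0.03 log units; within the scatter) are both small substituent additions, and neither moved the number beyond the scatter.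

Compound 4 `C=CC(=O)N1CC[C@H](N2C(=O)N(c3ccccc3)Cc3cnc(Nc4ccc(C5CCN(C)CC5)cc4)nc32)C1` carries a different kind of change: 1-methylpiperidin-4-yl in place of 4-methylpiperazin-1-yl on an aromatic carbon, on an aromatic carbon of a six-membered aromatic ring of carbon only. Going by the values given here, no measured step exchanges one of these two groups for the other, so the measured steps bear on it only loosely. The expectation for compound 4 is a 1.2-fold lower number from compound 1 to compound 4 (0.06 log units; within the scatter), a step not beyond the scatter, so the estimate for compound 4 in this assay is 2000 ng.h/mL, with a range from 800 ng.h/mL to 5000 ng.h/mL.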

Compound 4, area under the concentration-time curve: 1310 ng.h/mL
The estimate for compound 4 lay 1.5-fold (0.18 log units) above the measured number; measured number inside the range.
By their numbers in this assay, from the lowest: compounds 4, 2, 1 and 3 (each within the scatter of the next).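

Exchanging 4-methylpiperazin-1-yl for 1-methylpiperidin-4-yl, on an aromatic carbon para to a large group, gives in this assay a 1.8-fold lower number from compound 1 to compound 4 (0.25 log units; within the scatter) and so stays within the scatter. Unlike the small additions in compound 2 and compound 3, this change replaces the whole group, showing that a ring with 1 hetero atom can stand here in place of one with 2 without a step beyond the scatter. No available evidence accounts for the size of this step.

Open, as far as these compounds go, is whether a morpholine or a dimethylamino group at this position would also stay within the scatter. Also open, from the compounds shown here alone, is how 1-methylpiperidin-4-yl behaves alongside the methoxy of compound 2 or the methyl of compound 3.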